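The source may report more compounds than this note shows. Statements on the series, on what has been measured and on what is new or still open speak of the compounds shown alone.

Of the compounds shown here, three of one family have been measured in a functional assay on HCT-116 cells (Homo sapiens) for antiproliferative activity, read by MTT assay, with a stated time of 72 h; a lower number here means a stronger inhibitor, a higher number a weaker inhibitor. Compound 1 `CC(C)CNC(=N)NC(=N)Nc1ccc(C(F)(F)F)cc1` gives 3500 nM in this assay. Compound 3 `CC(C)NC(=N)NC(=N)Nc1ccc(C(F)(F)F)cc1` gives 4800 nM in this assay. Compound 2 `CC(C)CNC(=N)NC(=N)Nc1ccc(F)cc1F` gives 21100 nM in this assay, the highest of the three numbers and therefore the weakest inhibitor among them, with both other values lying well beyond the usual scatter from it.

Compound 4 `N=C(NC(=N)NC1CCCC1)Nc1ccc(F)cc1F` has not yet been measured. It differs from compound 2 in one place: cyclopentyl in place of isobutyl on an amine nitrogen. Among the measured compounds shown here, only one measured step speaks to a change of this kind, the swap of one small alkyl group for another on the same amine nitrogen, a 1.4-fold higher number from compound 1 to compound 3 (0.14 log units; within the scatter). That step stayed within the scatter, so the data give no sign that the group on this nitrogen moves the number much in either direction. Nothing measured tells what a cyclopentyl does differently from an isobutyl or an isopropyl.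

On that basis no step beyond the scatter is expected from compound 2 to compound 4, so compound 4 is estimated at 18000 nM, with a likely range from 7000 nM to 45000 nM. The step this estimate implies is a 1.2-fold lower number from compound 2 to compound 4 (0.07 log units; within the scatter).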

Compound 4, half-maximal inhibitory concentration: 29500 nM
Compound 4: middle estimate off by 1.6-fold (0.21 log units), on the low side; low and high end bracket the measured number.
By their numbers in this assay, from the lowest: compounds 1 and 3 (each within the scatter of the next); then compounds 2 and 4 (each within the scatter of the next).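

In this assay, cyclopentyl in place of isobutyl on this amine nitrogen gives a 1.4-fold higher number from compound 2 to compound 4 (0.15 log units; within the scatter). Among the compounds shown here, until now, the only change seen at this nitrogen was one open alkyl chain for another, so this is the first sign that a group containing a ring can stand here without a step beyond the scatter. It also extends the picture to a second pair: the earlier step, a 1.4-fold higher number from compound 1 to compound 3 (0.14 log units; within the scatter), came from compounds carrying trifluoromethyl, while the new one comes from compounds carrying fluorine on the shared core, and no listed step at this nitrogen goes against this; nothing measured here explains why the number responds so little to these swaps.

As far as these compounds go, whether cyclopentyl would behave the same way alongside the trifluoromethyl of compound 1 remains open, since a step at this nitrogen says nothing certain about a different core. Also open, from the compounds shown here alone, is what a cyclohexyl, a phenyl, or a chain ending in an amine or a hydroxyl group would do on this nitrogen, and whether any such group would give a step beyond the scatter.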